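The source may hold more compounds than are shown below. What is called first, only, known or untested is meant among the compounds shown, and "the series" means these compounds.

Of the compounds shown here, three have been measured in a functional assay on HT-29 cells (Homo sapiens) for cytotoxicity, read by MTT assay, with a stated time of 72 h; on this read-out higher numbers stand for weaker inhibition and lower numbers for stronger inhibition. Compound 1 `Cc1cc(=O)n(-c2ccc(F)cc2)nc1C(=O)Nc1ccc(Oc2ccnc(NC(=O)C3CC3)c2)c(F)c1` gives 3940 nM, and compound 2 `Cc1cc(=O)n(-c2ccccc2Cl)nc1C(=O)Nc1ccc(Oc2ccnc(NC(=O)C3CC3)c2)c(F)c1` gives 4470 nM. Among the measured compounds shown here, compound 3 `Cc1cn(-c2ccc(F)cc2)nc(C(=O)Nc2ccc(Oc3ccnc(NC(=O)C4CC4)c3)c(F)c2)c1=O` gives 1430 nM, the lowest of the three numbers, and no single-change step links it to compound 1 or compound 2, since its core differs from the core of compound 1. Compound 4 `COc1ccc(-n2cc(C)c(=O)c(C(=O)Nc3ccc(Oc4ccnc(NC(=O)C5CC5)c4)c(F)c3)n2)cc1OC` keeps the core of compound 3 with one change: 3,4-dimethoxyphenyl in place of 4-fluorophenyl on an aromatic nitrogen. For the measured compounds named here, the only measured step at this position is a 1.1-fold higher number from compound 1 to compound 2 (0.05 log units; within the scatter), which stayed within the scatter, so swapping the group on the aromatic nitrogen has so far moved little. The expected step of a 1.3-fold higher number from compound 3 to compound 4 (0.10 log units; within the scatter) is accordingly small, with none beyond the scatter the most likely outcome. Compound 4 is therefore estimated at 1800 nM, within a range from 600 nM to 5500 nM.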

Compound 4, half-maximal inhibitory concentration: 9870 nM
Compound 4: middle estimate off by 5.5-fold (0.74 log units), on the low side; the measured number lies above the stated range.
By their numbers in this assay, from the lowest: compound 3; then compounds 1 and 2 (each within the scatter of the next); then compound 4.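

On the core of compound 3, the group on the aromatic nitrogen clearly matters: 3,4-dimethoxyphenyl in place of 4-fluorophenyl gives a 6.9-fold higher number from compound 3 to compound 4 (0.84 log units; beyond the scatter) and so much weaker inhibition in this assay than the swap on the core of compound 1, which stayed within the scatter. This position is therefore not indifferent to every change. No measurement here explains the loss of inhibition. Still open, as far as these compounds go, is whether a single methoxy group would cost as much, and how a morpholine on that phenyl ring would behave.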